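This account rests on a few compounds, and the source may have more. Where it says the series, first, only, none or still open, it means among the compounds named here.

Values in a functional assay (aorta) for inhibition, with Rattus norvegicus as the target; a lower number here means a stronger inhibitor, a higher number a weaker inhibitor:
- compound 1 `Cc1nsc(-c2ccc(N3CCN(c4cccc(C(F)(F)F)c4)CC3)nc2)n1`: 5 nM
- compound 2 `CNc1nsc(-c2ccc(N3CCN(c4cccc(C(F)(F)F)c4)CC3)nn2)n1`: 3 nM
- compound 3 `Cc1nsc(-c2ccc(N3CCN(c4cccc(C#N)c4)CC3)nn2)n1`: 3 nM

In this assay compound 3 stands level with compound 2, and compound 1 lies within the scatter of both, so the three values form a single tight group.

Compound 4 `COc1cccc(N2CCN(c3ccc(-c4nc(C)ns4)nn3)CC2)c1` is the next one to read. It takes methoxy in place of cyano on an aromatic carbon, the same difference being 3-cyanophenyl to 3-methoxyphenyl: methoxy in place of cyano on an aromatic carbon. Among the compounds with values here, no measured pair isolates this change, and none of the measured compounds carries methoxy, so the data offer no direct guide to its size. The starting point is compound 3 at 3 nM. A modest rise in the number is expected, with no change beyond the scatter also quite possible. The expected move is a 2.0-fold higher number from compound 3 to compound 4 (0.30 log units; within the scatter). The estimated value for compound 4 is 6 nM, with an expected range of 2 nM to 20 nM.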

Compound 4, half-maximal inhibitory concentration: 7 nM
For compound 4 the middle estimate is 1.2-fold (0.07 log units) below the measured one; the range from low to high includes it.
By their numbers in this assay, from the lowest: compounds 2, 3, 1 and 4 (each within the scatter of the next, the first and the last beyond it).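

In this assay, within the data shown here, the exchange of cyano for methoxy on the aromatic carbon gives a 2.3-fold higher number from compound 3 to compound 4 (0.37 log units; beyond the scatter) and is the first single-place step, so this position does register a change of group, though a modest one. The step appears with the heavy-atom count and the hydrogen-bond acceptor count unchanged between the leaving and entering groups, so neither count separates cyano from methoxy here. Nothing measured on these compounds bears on the origin of this step.

This single pair leaves open whether the same exchange would move the number by a similar amount on the core of compound 1. Also open, as far as these compounds go, is how an amine, a carboxylic acid or a longer alkoxy chain at this place would compare with compound 3 and compound 4.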